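The source may hold more compounds than are shown below. What is called first, only, known or untested is meant among the compounds shown, and "the series" means these compounds.

Measured in a functional assay on MGC-803 cells (Homo sapiens) for antiproliferative activity, read by MTT assay, with a stated time of 48 h; a higher number here means a weaker inhibitor, a lower number a stronger inhibitor:
- compound 1 `COc1ccc(CN(C(=O)CSc2nc3ccccc3s2)c2cc(OC)c(OC)c(OC)c2)cc1C`: 6360 nM
- compound 2 `COc1ccc(CN(C(=O)CSc2nc3ccccc3s2)c2cc(OC)c(OC)c(OC)c2)cc1N=[N+]=[N-]`: 187 nM
- compound 3 `COc1ccc(CN(C(=O)CSc2nc3ccccc3s2)c2cc(OC)c(OC)c(OC)c2)cc1`: 163 nM

Compound 2 sits with compound 3 at the low end of these three numbers: a 1.1-fold lower number from compound 2 to compound 3 (0.06 log units; within the scatter) stays within the scatter, and a 34-fold lower number from compound 1 to compound 2 (1.53 log units; beyond the scatter) is large.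

The next change gives compound 4 `COc1cc(CN(C(=O)CSc2nc3ccccc3s2)c2cc(OC)c(OC)c(OC)c2)cc(OC)c1OC`, with 3,4,5-trimethoxyphenyl in place of 3-azido-4-methoxyphenyl on a saturated chain carbon bound to an amide-type nitrogen.

Among the measured compounds shown here, all three measured steps exchange one group on this aromatic ring, but no measured compound carries the entering group. These steps therefore bear on the change only indirectly. The azido group of compound 2 shows that a group on that ring carbon can leave the number unchanged, with a 1.1-fold lower number from compound 2 to compound 3 (0.06 log units; within the scatter). The methyl group of compound 1 shows that one can raise it sharply, with a 39-fold lower number from compound 1 to compound 3 (1.59 log units; beyond the scatter).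

A moderate move towards a higher number in this assay is expected, smaller than the methyl step. The expected step is a 2.7-fold higher number from compound 2 to compound 4 (0.43 log units; beyond the scatter). For compound 4 the estimate is 500 nM, within an expected range of 110 nM to 3000 nM.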

Compound 4, half-maximal inhibitory concentration: 45700 nM
Estimate against measurement, compound 4: 91-fold (1.96 log units) below; the measured number lies above the stated range.
By their numbers in this assay, from the lowest: compounds 3 and 2 (each within the scatter of the next); then compound 1; then compound 4.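

In this assay, 3,4,5-trimethoxyphenyl on the saturated chain carbon bound to an amide-type nitrogen gives the largest steps seen in the series, with a 240-fold higher number from compound 2 to compound 4 (2.39 log units; beyond the scatter) and a 280-fold higher number from compound 3 to compound 4 (2.45 log units; beyond the scatter) both large, while a 7.2-fold higher number from compound 1 to compound 4 (0.86 log units; beyond the scatter) is modest yet still places compound 4 beyond the methyl-bearing compound 1. Among the compounds shown here, the earlier compounds showed only that this ring could give either a number within the scatter or a sharply higher one, whereas compound 4 extends the higher end well past the methyl step. No measured evidence accounts for this result.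

Still open, going by these compounds, is whether a single methoxy group, an amine or a hydroxyl group on the ring carbon that carries azido in compound 2 stays close to compound 3 or moves towards compound 4. Also open, on these data alone, is whether 3,4,5-trimethoxyphenyl gives a step of this size on any other core.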